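The source may hold more compounds than are shown below. What is called first, only, known or untested is meant among the compounds shown, and "the series" means these compounds.

Measured compounds in the series:

Compound 1, `COc1cccc(NC(=O)c2ccc3cccc(O)c3n2)c1`: in an ADME assay on THP-1 cells (Homo sapiens) for cytotoxicity, read by WST assay, with a stated time of 24 h (on this read-out higher numbers stand for weaker inhibition and lower numbers for stronger inhibition), compound 1 gives > 30000 nM, which is a limit of the assay and not a number.
Compound 2, `Cc1ccccc1NC(=O)c1ccc2cccc(O)c2n1`: in this assay compound 2 gives > 30000 nM, again a limit.
Compound 3, `O=C(Nc1ccccc1Cl)c1ccc2cccc(O)c2n1`: in this assay compound 3 gives > 30000 nM, also a limit.

Compound 1 therefore stands nowhere on a scale; only a limit is known for it, and the other two values shown are limits as well, so no ordering among the three is possible. Among the compounds with values here, the one step between compounds that differ in one place, a step that the two limits leave unreadable from compound 2 to compound 3, is unreadable for the same reason. What all three share is the limit of > 30000 nM in this assay, at which 3 of the 3 values shown sit.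

Compound 4, `O=C(Nc1cccc([N+](=O)[O-])c1)c1ccc2cccc(O)c2n1`, differs from compound 1 by nitro in place of methoxy on an aromatic carbon. Within the data shown here, no measured step bears on this change: the only step recorded, chloro in place of methyl, cannot be read, and no nitro group appears among the measured compounds. What the series does show is that every change made so far to the ring bearing the amide nitrogen has left the read-out at its limit.

On that basis compound 4 is expected to remain at the limit in this assay, with the estimate 40000 nM, between 15000 nM and 100000 nM, so that the expected step that the limit leaves unreadable from compound 1 to compound 4 is none beyond the scatter.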

Compound 4, half-maximal inhibitory concentration: > 30000 nM
Compound 4 was reported as a limit; the forecaster's own chance of this, stated with the estimate: 85%; the middle value lies beyond the limit too.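

No new step can be read: compound 1 and compound 4 are both known only as limits, so the change from methoxy to nitro cannot be sized, and the series stays where it was: the limit of > 30000 nM in this assay, at which 4 of the 4 values shown sit.

The compounds shown leave open what actual value any of the four has in this assay, and so whether any of these changes shifts it.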